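The compounds below may be only part of what the source reports. "The series", "measured", "known", "first", "only" and "open" are said of these compounds alone.

Values in a functional assay on Bel7402/5-FU cells (Homo sapiens) for antiproliferative activity, read by MTT assay, with a stated time of 72 h; a lower number here means a stronger inhibitor, a higher number a weaker inhibitor:
- compound 1 `C=C1C(=O)O[C@H]2[C@H]1CC/C(COC(=O)Cn1cc(F)c(=O)n(Cc3ccc(F)cc3)c1=O)=C\CC[C@@]1(C)O[C@@H]21`: 1140 nM
- compound 2 `C=C1C(=O)O[C@H]2[C@H]1CC/C(COC(=O)Cn1cc(F)c(=O)n(Cc3cccc(F)c3)c1=O)=C\CC[C@@]1(C)O[C@@H]21`: 3700 nM

Compound 2 has the higher, weaker number of the two. Compound 3 `C=C1C(=O)O[C@H]2[C@H]1CC/C(COC(=O)Cn1cc(F)c(=O)n(Cc3ccc(F)cc3F)c1=O)=C\CC[C@@]1(C)O[C@@H]21` differs from it by 2,4-difluorophenyl in place of 3-fluorophenyl on a saturated chain carbon bound to an aromatic nitrogen, with 2,4-difluorophenyl in place of 3-fluorophenyl on a saturated chain carbon bound to an aromatic nitrogen. Going by the values given here, the only measured step bearing on this is a 3.2-fold higher number from compound 1 to compound 2 (0.51 log units; beyond the scatter), which is modest. The new group keeps the fluorine numbered 4, as in the 4-fluorophenyl of compound 1, so movement toward a lower number in this assay is expected. The expected step is a 2.2-fold lower number from compound 2 to compound 3 (0.34 log units; beyond the scatter). The estimate for compound 3 is 1700 nM, with an expected range of 700 nM to 4000 nM.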

Compound 3, half-maximal inhibitory concentration: 5010 nM
Compound 3: the middle estimate sits 2.9-fold (0.47 log units) below what was measured, outside the stated range (above it).
By their numbers in this assay, from the lowest: compound 1; then compounds 2 and 3 (each within the scatter of the next).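

In this assay, 2,4-difluorophenyl in place of 3-fluorophenyl gives a 1.4-fold higher number from compound 2 to compound 3 (0.13 log units; within the scatter) and so does not separate compound 2 from compound 3 at this saturated chain carbon bound to an aromatic nitrogen. Fluoro in place of hydrogen on an aromatic carbon gives a 4.4-fold higher number from compound 1 to compound 3 (0.64 log units; beyond the scatter) and shows that adding fluorine to the 4-fluorophenyl of compound 1 does not keep its lower number. No measurement on hand accounts for this result.

From the compounds shown here alone, whether unsubstituted phenyl, 4-chlorophenyl or 4-methoxyphenyl at this place would give a number lower than that of compound 1 stays open.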